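From 6-Methylpyridin-3-yl to 4-Fluorobenzyl: One Substitution

The source may hold more compounds than are shown below. What is called first, only, known or untested is meant among the compounds shown, and "the series" means these compounds.

Compound 1, `Fc1ccc(-c2noc(C3CCc4c(nnn4C4CCOC4)C3)n2)cc1`: 398 nM
Compound 2, `Cc1ccc(-c2noc(C3CCc4c(nnn4C(C)(C)C)C3)n2)cn1`: 1580 nM

Both compounds were tested in a functional assay on U2OS cells for positive allosteric modulation of metabotropic glutamate receptor 5 (Homo sapiens), read by calcium flux, in the presence of a further agent that is not named here; a higher number here means that more compound is needed for the effect, a lower number that less compound is needed. Compound 2 gives the higher of the two numbers, so more of it is needed for the effect; compound 1 sits at a lower value, and that gap lies beyond the usual scatter of the measurement.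

Compound 3, `CC(C)(C)n1nnc2c1CCC(c1nc(Cc3ccc(F)cc3)no1)C2`, has not yet been measured. It differs from compound 2 in one place: 4-fluorobenzyl in place of 6-methylpyridin-3-yl on an aromatic carbon. Among the measured compounds shown here, no measured pair shows this exact change, and compound 1 differs from compound 2 in more than one place, so the two measured values only show where compound 2 stands, not what this substitution does.

The expected step is a 1.6-fold lower number from compound 2 to compound 3 (0.20 log units; within the scatter), a modest move toward a lower number, though a result within the scatter would not surprise. Compound 3 is estimated at 1000 nM, within a range from 300 nM to 4000 nM.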

Compound 3, half-maximal effective concentration: 20 nM
The estimate for compound 3 lay 50-fold (1.70 log units) above the measured number, and the stated range ends above it.
By their numbers in this assay, from the lowest: compound 3; then compound 1; then compound 2.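

Replacing 6-methylpyridin-3-yl with 4-fluorobenzyl on this aromatic carbon, with the rest of compound 2 left unchanged, gives a 79-fold lower number from compound 2 to compound 3 (1.90 log units; beyond the scatter), so the group at this position can strongly change how much compound is needed. The earlier values could not show this, as compound 1 differs from compound 2 in more than one place. Nothing available here explains why this single change has so large an effect.

The new group differs from the old one in several ways at once, including its ring, its fluorine and its link to the five-membered ring, and the compounds shown do not separate these features. Plain benzyl without fluorine, or 2-phenylethyl with a longer chain to the ring, would be among the groups that could begin to tell them apart.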